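Adding a Third Methoxy Group to a Chalcone-Pyrazole Series

The source may report more compounds than this note shows. Statements on the series, on what has been measured and on what is new or still open speak of the compounds shown alone.

The measured compounds are:
compound 1 `COc1cc(-c2cc(/C=C/C(=O)c3ccc(N)cc3)[nH]n2)cc(OC)c1OC` with 8930 nM in a functional assay on SK-MEL-28 cells (Homo sapiens) for inhibition, read by sulforhodamine B assay, with a stated time of 48 h; on this read-out lower numbers stand for higher toxicity in this test and higher numbers for lower toxicity in this test;
compound 2 `COc1ccc(C(=O)/C=C/c2cc(-c3cc(OC)c(OC)c(OC)c3)n[nH]2)cc1OC` with 6250 nM in this assay;
compound 3 `COc1ccc(-c2cc(/C=C/C(=O)c3ccc(N)cc3)[nH]n2)cc1OC` with 21100 nM in this assay.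

Compound 3 and compound 1 differ by methoxy in place of hydrogen on an aromatic carbon. That change brings a 2.4-fold lower number from compound 3 to compound 1 (0.37 log units; beyond the scatter). Compound 1 and compound 2 differ by 3,4-dimethoxyphenyl in place of 4-aminophenyl on a carbonyl carbon, and the step is a 1.4-fold lower number from compound 1 to compound 2 (0.15 log units; within the scatter). The difference between the cores of compound 2 and compound 3 is not broken down here; their values show a gap, with compound 3 giving the higher number.

The unmeasured compound 4 `COc1cc(C(=O)/C=C/c2cc(-c3cc(OC)c(OC)c(OC)c3)n[nH]2)cc(OC)c1OC` differs from compound 2 by methoxy in place of hydrogen on an aromatic carbon. This is the same change that was made between compound 3 and compound 1, and it occurs twice among the compounds shown. For compound 4 the step is expected to be a 2.1-fold lower number from compound 2 to compound 4 (0.32 log units; beyond the scatter), resting on the earlier step of a 2.4-fold lower number from compound 3 to compound 1 (0.37 log units; beyond the scatter) at the same kind of place. Compound 4 is therefore estimated at 3000 nM, between 1500 nM and 6500 nM.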

Compound 4, concentration lethal to 50% of the cells: 6070 nM
Compound 4: the middle estimate sits 2.0-fold (0.31 log units) below what was measured; measured number inside the range.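

In this assay, methoxy in place of hydrogen on an aromatic carbon of compound 2 gives a 1.0-fold lower number from compound 2 to compound 4 (0.01 log units; within the scatter), so on this core the two compounds cannot be told apart. Set beside the earlier step on the other core, this result cannot be separated from it, even though only the earlier step lies beyond the scatter on its own: the same change on two cores in this assay, a 2.4-fold lower number (0.37 log units; beyond the scatter) from compound 3 to compound 1 and a 1.0-fold lower number (0.01 log units; within the scatter) from compound 2 to compound 4, 2.3-fold (0.36 log units) apart, within the scatter of two such steps. The pair therefore does not show that the change depends on the core, yet neither does it show that the earlier step carries over at the same size, and two steps are too few to settle either reading.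

The compounds shown leave open whether a hydroxyl group, an ethoxy group or a fluorine atom on the same aromatic carbon would read differently from methoxy in this assay. They also leave open whether the step would hold on further cores, such as one carrying a carboxylic acid in place of the amine of compound 1.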